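Solubility at the chain end: amino replaced by methoxy

The source may report more compounds than this note shows. Statements on the series, on what has been measured and on what is new or still open speak of the compounds shown alone.

Among the measured compounds shown here, compound 2 `NCCCNc1nnc(-c2ccc(F)c(F)c2Nc2ccc(I)cc2F)o1` is the only member with a definite number: in a physicochemical assay for solubility, read by HPLC, in phosphate buffer, at pH 6.5 (on this read-out lower numbers stand for lower solubility and higher numbers for higher solubility), compound 2 gives 5.4 ug/mL. Compound 1 `OCCCNc1nnc(-c2ccc(F)c(F)c2Nc2ccc(I)cc2F)o1` is reported as a limit only, since in this assay compound 1 gives < 3 ug/mL. For the measured compounds named here, the one measured step on this chain is an at least 1.8-fold higher number from compound 1 to compound 2 (0.25 log units; that floor lies within the scatter), and its size rests on (the limit of < 3 ug/mL in this assay, at which 1 of the 2 values shown sits), so only a floor is known.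

Compound 3 `COCCCNc1nnc(-c2ccc(F)c(F)c2Nc2ccc(I)cc2F)o1` differs from compound 2 by methoxy in place of amino on a saturated chain carbon, three bonds along the chain from a nitrogen on an aromatic ring. Going by the values given here, the hydroxy-to-amino step is the only measured comparison that bears on this change, and it points in the opposite direction, because an at least 1.8-fold higher number from compound 1 to compound 2 (0.25 log units; that floor lies within the scatter) accompanied the arrival of the amino that now leaves. A fall in this assay is therefore expected from compound 2 to compound 3, estimated as a 2.7-fold lower number from compound 2 to compound 3 (0.43 log units; beyond the scatter). For compound 3 the expected value in this assay is 2 ug/mL, with a range of 0.8 ug/mL to 5 ug/mL, and a report as a limit rather than a number is quite possible.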

Compound 3, solubility: < 3 ug/mL
Compound 3: only a limit was reported; the forecaster's own chance of this, stated with the estimate: 55%; the middle value does not contradict the limit.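

Methoxy in place of amino at this chain end gives, in this assay, an at least 1.8-fold lower number from compound 2 to compound 3 (0.25 log units; that floor lies within the scatter), and that step is a floor only. Compound 3 is reported as a limit, so the hydroxy of compound 1 and the methoxy of compound 3 now both end without a definite number, and among the three chain ends shown only the amino of compound 2 has one. The pair that differs by methyl in place of hydrogen on an oxygen on a saturated carbon cannot be read, as both compounds stop at the same limit: the limit of < 3 ug/mL in this assay, at which 2 of the 3 values shown sit.

Going by these compounds, the true values of compound 1 and compound 3, and so the real size of both floors, stay open. The compounds shown also leave open how a dimethylamino group, a carboxylic acid or a longer chain ending in an amine would read at this position.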